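A few compounds are considered here, and "the series" means these few. Any claim that something is new, unique, unknown or untested is made for them only; others in the source may bear on it.

Working notes on the series in an ADME assay on HOS cells (Homo sapiens) for cytotoxicity; a higher number here means that more compound is tolerated, a lower number that less compound is tolerated.

Within the data shown here, compound 3 `CN1CCC(n2c(CN(C)C3CCCc4cccnc43)nc3ccccc32)CC1` gives 16000 nM in this assay and sits at the upper end of the three numbers measured so far. Compound 1 `CN1CCC(Cn2c(CN(C)C3CCCc4cccnc43)nc3ccccc32)C1` gives 15000 nM, and the step of a 1.1-fold higher number from compound 1 to compound 3 (0.03 log units; within the scatter) does not separate the two. Compound 2 `CN1CCC[C@H](Cn2c(CN(C)[C@H]3CCCc4cccnc43)nc3ccccc32)C1` is a stereodefined form of compound 1. Among the measured compounds shown here, compound 2 gives 3600 nM, which is the lowest of the three values and lies beyond the scatter from compound 3; no single-point step to compound 2 is counted here, so only the two numbers themselves can be set side by side.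

Compound 4 `CN1CCCC(Cn2c(CN(C)C3CCCc4cccnc43)nc3ccccc32)C1` differs from compound 3 in one place: (1-methylpiperidin-3-yl)methyl in place of 1-methylpiperidin-4-yl on an aromatic nitrogen

For the measured compounds named here, the only measured step that bears on this change is a 1.1-fold higher number from compound 1 to compound 3 (0.03 log units; within the scatter), where an exchange of the same kind, between a ring attached directly to the aromatic nitrogen and a ring carried on a methylene, left the number within the scatter. On that basis the move from compound 3 to compound 4 is expected to stay within the scatter as well, with no direction assigned; the estimated step is a 1.1-fold lower number from compound 3 to compound 4 (0.06 log units; within the scatter). Compound 4 is therefore estimated at 14000 nM, with a range from 6000 nM to 30000 nM.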

Compound 4, half-maximal cytotoxic concentration: 3000 nM
Estimate against measurement, compound 4: 4.7-fold (0.67 log units) above; the measured number lies below the stated range.
By their numbers in this assay, from the lowest: compounds 4 and 2 (each within the scatter of the next); then compounds 1 and 3 (each within the scatter of the next).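

In this assay this position on the aromatic nitrogen proves sensitive to the group it carries: replacing 1-methylpiperidin-4-yl with (1-methylpiperidin-3-yl)methyl gives a 5.3-fold lower number from compound 3 to compound 4 (0.73 log units; beyond the scatter). The ring on the methylene matters too, since 1-methylpiperidin-3-yl in place of 1-methylpyrrolidin-3-yl on the saturated chain carbon gives a 5.0-fold lower number from compound 1 to compound 4 (0.70 log units; beyond the scatter), so the earlier 1.1-fold higher number from compound 1 to compound 3 (0.03 log units; within the scatter) does not extend to every ring carried on a methylene. Compound 2 has the same atoms and bonds as compound 4, and a 1.2-fold lower number from compound 2 to compound 4 (0.08 log units; within the scatter) places the two together at the low end of the series, but no particular configuration can be credited with that result because of one fact: the fact that one of compounds 2 and 4 is drawn with a defined configuration and the other without, at the place where they differ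

Still open, from the compounds shown here alone, is whether the lower number goes with the methylene link combined with a six-membered ring or with the way the piperidine is attached in compound 4, a question that a (1-methylpiperidin-4-yl)methyl group would bear on directly. Also open, going by these compounds, is how a longer chain between the piperidine and the aromatic nitrogen would read in this assay.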